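Swapping ethyl for cyano on the shared core

The source may hold more compounds than are shown below. What is called first, only, known or untested is meant among the compounds shown, and "the series" means these compounds.

Measured in a physicochemical assay for lipophilicity, using the shake flask method, measured as octanol-water partition, with a stated time of 30 min, at pH 7.4; on this read-out lower numbers stand for lower lipophilicity and higher numbers for higher lipophilicity:
- compound 1 `O=C(O)CCc1ccc(-c2ccc3cnn(-c4ccccn4)c3c2)cc1`: 2.4
- compound 2 `CCc1nn(-c2ccccn2)c2cc(-c3ccc(CCC(=O)O)cc3)ccc12`: 3.3

For the measured compounds named here, compound 2 stands highest of the two numbers, with compound 1 the only neighbour. Next comes compound 3 `N#Cc1nn(-c2ccccn2)c2cc(-c3ccc(CCC(=O)O)cc3)ccc12`, with cyano in place of ethyl on an aromatic carbon. Going by the values given here, one measured step bears on this place: a number 0.90 log units higher from compound 1 to compound 2 (beyond the scatter), modest and beyond the scatter. Among the compounds with values here, no measured compound carries cyano, so the size remains uncertain. A downward move of similar size is expected in this assay. The estimated change is a number 0.80 log units lower from compound 2 to compound 3 (beyond the scatter). For compound 3 the expected value is 2.5, within an estimated range of 2 to 3.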

Compound 3, distribution coefficient: 3
Compound 3: middle estimate off by 0.50 log units, on the low side, and the stated range covers the measured number.
By their numbers in this assay, from the lowest: compound 1; then compounds 3 and 2 (each within the scatter of the next).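

In this assay, cyano and ethyl on this aromatic carbon are not separated: a number 0.30 log units lower from compound 2 to compound 3 (within the scatter). Hydrogen is separated from cyano as well as from ethyl, with a number 0.60 log units higher from compound 1 to compound 3 (beyond the scatter), so ethyl is no longer the only group shown to give a step beyond the scatter at this position. Nothing measured on the series offers an account of this result.

As far as these compounds go, whether an amine, a methoxy group or a longer alkyl chain on the same carbon would fall with cyano and ethyl remains open.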